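This account rests on a few compounds, and the source may have more. Where it says the series, first, only, none or still open, it means among the compounds named here.

Measured so far:
- compound 1, `Nc1ccccc1NC(=O)c1ccc(CSC(=S)N2CCN(C(c3ccccc3)c3ccccc3)CC2)cc1`, gives 8.7% in a functional assay on A-375 cells (Homo sapiens) for antiproliferative activity, read by CCK-8 assay, with a stated time of 72 h, tested at 2 uM; a higher number here means a stronger effect of the compound at the concentration tested, a lower number a weaker effect
- compound 2, `Nc1ccccc1NC(=O)c1ccc(CSC(=S)N2CCc3ccccc32)cc1`, gives 25.7% in this assay

Compound 2 stands highest of the two numbers in hand; its nearest neighbour is compound 1, whose value lies beyond the scatter below it. Among the compounds with values here, no step between a pair of measured compounds that differ in one place is available, so nothing measured tells how a change at the thiocarbonyl carbon moves the read-out.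

The next compound is compound 3, `Nc1ccccc1NC(=O)c1ccc(CSC(=S)N2CCCC2)cc1`. It differs from compound 2 as follows: pyrrolidin-1-yl in place of 2,3-dihydro-1H-indol-1-yl on a thiocarbonyl carbon. The entering group keeps the five-membered non-aromatic ring with one hetero atom and drops the six-membered aromatic ring of carbon only.

The step in this assay is expected to be small and, if anything, downward, probably not beyond the scatter: a number 7.7 percentage points lower from compound 2 to compound 3 (within the scatter). For compound 3 the estimate is 18%, with a range from 5% to 34%.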

Compound 3, a percentage reported as inhibition, at one concentration (the size of the read-out at that concentration, not a potency): 30.2%
Estimate against measurement, compound 3: 12.2 percentage points below; the measured number falls inside the stated range.
By their numbers in this assay, from the lowest: compound 1; then compounds 2 and 3 (each within the scatter of the next).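

In this assay, within the data shown here, the change on the thiocarbonyl carbon, pyrrolidin-1-yl in place of 2,3-dihydro-1H-indol-1-yl, is a number 4.5 percentage points higher from compound 2 to compound 3 (within the scatter) and gives the first reading of this position with everything else held the same. The six-membered aromatic ring of carbon only can therefore leave this group, with the five-membered non-aromatic ring kept, without a step that stands clear of the scatter at this single concentration. Nothing at hand explains the result, and no independent data on these groups accompany it.

Open, as far as these compounds go, is whether the ring size on the thiocarbonyl carbon matters, as a piperidin-1-yl or morpholin-4-yl group, or an open-chain dimethylamino group, would show. Also open, from the compounds shown here alone, is whether compounds 2 and 3 would stay together in a potency measurement rather than a read-out at one concentration.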